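Carboxy for acetamido on the benzoxazole-type core of compound 1

A few compounds are considered here, and "the series" means these few. Any claim that something is new, unique, unknown or untested is made for them only; others in the source may bear on it.

Two compounds carry numbers in a functional assay on CAL1 cells for inhibition of chemerin-like receptor 1 (Homo sapiens), with a stated time of 45 min; on this read-out lower numbers stand for stronger inhibition and higher numbers for weaker inhibition. Compound 1 `CCCCN(c1nc2c(NC(C)=O)cccc2o1)[C@H](C)c1ccc(-c2ccccc2-c2nnn[nH]2)cc1` gives 22 nM and stands highest of the two. Compound 2 `C[C@H](c1ccc(-c2cc(F)ccc2-c2nc(=O)o[nH]2)cc1)N(CC1CC1)c1nc2c(C(=O)O)cccc2o1` gives 2.3 nM in this assay, a lower number, beyond the scatter; the two differ in several places at once, so the gap cannot be tied to any single change.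

Compound 3 `CCCCN(c1nc2c(C(=O)O)cccc2o1)[C@H](C)c1ccc(-c2ccccc2-c2nnn[nH]2)cc1` has not been measured. It differs from compound 1 in one place: carboxy in place of acetamido on an aromatic carbon. Compound 2 also bears a carboxy on its core, and its value is the only hint in the data that a carboxy at this place is compatible with a low number, though the other differences of compound 2 leave that hint weak.

In this assay the expected step is a 3.1-fold lower number from compound 1 to compound 3 (0.50 log units; beyond the scatter). Such a downward step would still leave compound 3 well short of compound 2. For compound 3 the estimated value in this assay is 7 nM, expected between 2 nM and 25 nM.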

Compound 3, half-maximal inhibitory concentration: 17 nM
The estimate for compound 3 lay 2.4-fold (0.39 log units) below the measured number, within the range that was stated.
By their numbers in this assay, from the lowest: compound 2; then compounds 3 and 1 (each within the scatter of the next).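

In this assay, going by these compounds alone, carboxy in place of acetamido on an aromatic carbon, ortho to a fused ring and meta to a fused ring, gives a 1.3-fold lower number from compound 1 to compound 3 (0.11 log units; within the scatter) and so, in the first single-place comparison, the two groups cannot be told apart at this position. With the rest of the structure held constant, this position accepts either group on this read-out, and the change does not produce a step beyond the scatter. Steps to compound 2 cannot be read, as it differs from compound 1 and compound 3 in several places, so the carboxy it carries cannot be tied to its value, and no measurement available here offers an explanation for the result.

On these data alone, whether the same position also accepts a primary amine, a methyl ester, a plain hydrogen or a longer chain such as propionamido remains open. Also open, as far as these compounds go, is whether carboxy and acetamido stay equivalent when the butyl chain on the nitrogen is replaced by cyclopropylmethyl, the group found in compound 2.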